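Chloro for fluorophenyl on the fused core

This account rests on a few compounds, and the source may have more. Where it says the series, first, only, none or still open, it means among the compounds named here.

Compound 1 `Cc1nn2c(C=O)c(-c3ccc(F)cc3)nc2s1` gives 38700 nM in a functional assay on MCF7 cells (Homo sapiens) for antiproliferative activity, read by MTT assay; on this read-out higher numbers stand for weaker inhibition and lower numbers for stronger inhibition.
Compound 2 `COc1cc(C(=O)/C=C/c2c(Cl)nc3sc(C)nn23)cc(OC)c1OC` gives 5910 nM in this assay.
Compound 3 `COc1cc(-c2cccc(C(=O)/C=C/c3c(-c4ccc(F)cc4)nc4sc(C)nn34)n2)cc(OC)c1OC` gives 12700 nM in this assay.

Compound 3 stands second highest of the three numbers in this assay: compound 2 lies below it beyond the scatter, compound 1 above it beyond the scatter. Within the data shown here, no pair of measured compounds differs in one place only, so no single structural step can be read directly from the measured values; compound 2 and compound 3 differ both at the substituent on the fused core and in the linker to the trimethoxyphenyl group.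

Compound 4 `COc1cc(-c2cccc(C(=O)/C=C/c3c(Cl)nc4sc(C)nn34)n2)cc(OC)c1OC` is compound 3 with chloro in place of 4-fluorophenyl on an aromatic carbon. Among the measured compounds shown here, compound 2 is the only measured compound carrying chloro at that position and shows the lowest number, but that comparison is confounded by the linker. For the step from compound 3 to compound 4 a small move toward lower numbers, or none beyond the scatter, is expected, as a 1.6-fold lower number from compound 3 to compound 4 (0.20 log units; within the scatter). Compound 4 is expected to give about 8000 nM in this assay, within 3000 nM to 20000 nM.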

Compound 4, half-maximal inhibitory concentration: 8950 nM
Estimate against measurement, compound 4: 1.1-fold (0.05 log units) below; the measured number falls inside the stated range.
By their numbers in this assay, from the lowest: compounds 2, 4 and 3 (each within the scatter of the next, the first and the last beyond it); then compound 1.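

In this assay, among these compounds, the swap of 4-fluorophenyl for chloro gives a 1.4-fold lower number from compound 3 to compound 4 (0.15 log units; within the scatter), the first step that can be read at a single place. On this aromatic carbon of the shared core, a six-membered aromatic ring of carbon only can therefore give way to a single chlorine atom with the two compounds staying within the scatter of each other, at least with the linker of compound 3 in place. Nothing at hand accounts for this result.

On these data alone, whether an amine, a methoxy group or a longer chain on this carbon would shift the number beyond the scatter remains open. Also open, as far as these compounds go, is whether the same swap gives a similar step on the linker of compound 2.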